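The compounds below may be only part of what the source reports. "The series", "measured", "known", "first", "only" and "open" are said of these compounds alone.

Measured so far in a physicochemical assay for solubility, read by nephelometry, measured as kinetic solubility, with a stated time of 30 min; on this read-out lower numbers stand for lower solubility and higher numbers for higher solubility:
Compound 1 `CC(C)(O)CN1CCC(Oc2ccc([C@H]3CC[C@]4(CC3)OOC3(O4)C4CC5CC(C4)CC3C5)cc2)CC1`: 1.6 ug/mL
Compound 2 `N[C@H]1CC[C@@H](Oc2ccc([C@H]3CC[C@]4(CC3)OOC3(O4)C4CC5CC(C4)CC3C5)cc2)CC1`: 25 ug/mL

Compound 2 holds the higher of the two numbers, 25 ug/mL. The next molecule, compound 3 `CC1(C)CC(O)(COc2ccc([C@H]3CC[C@]4(CC3)OOC3(O4)C4CC5CC(C4)CC3C5)cc2)CC(C)(C)N1`, keeps the shared core and changes only the group on the oxygen on the aromatic ring: (4-hydroxy-2,2,6,6-tetramethylpiperidin-4-yl)methyl in place of 4-aminocyclohexyl on an oxygen on an aromatic ring.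

Among the compounds with values here, only one measured step touches this same place. It is a 16-fold higher number from compound 1 to compound 2 (1.19 log units; beyond the scatter), a large step beyond the scatter, in which 4-aminocyclohexyl replaces 1-(2-hydroxy-2-methylpropyl)piperidin-4-yl. The group entering compound 3 is, by name, a hydroxy-bearing piperidine, and so it looks more like the group of compound 1, which stands at 1.6 ug/mL, than like the group it replaces. A single step cannot show what lies behind that gap, and no measured compound carries the tetramethyl pattern, so the resemblance is only a weak guide.

The estimated change is a 2.5-fold lower number from compound 2 to compound 3 (0.40 log units; beyond the scatter), a fall expected to be smaller than the measured step. The estimate for compound 3 is 10 ug/mL, with an expected range of 2.5 ug/mL to 40 ug/mL.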

Compound 3, solubility: > 100 ug/mL
Compound 3: no number, only a limit (the forecaster's own chance of this, stated with the estimate: 8%); middle value at least 10-fold (1.00 log units) from the limit.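

In this assay compound 3 gives > 100 ug/mL, which is a limit of the assay and not a number: the limit of > 100 ug/mL in this assay, at which 1 of the 3 values shown sits.

Even so, the change of group gives an at least 4.0-fold higher number from compound 2 to compound 3 (0.60 log units; beyond the scatter), and the comparison with the lowest compound gives an at least 62-fold higher number from compound 1 to compound 3 (1.79 log units; beyond the scatter), so the group on an oxygen on an aromatic ring can now be seen to move this read-out upward from compound 2 as well as downward, as compound 1 showed. Compound 1 and compound 3 both carry a piperidine ring and a hydroxy group, yet they lie at opposite ends of the three compounds, so sharing those two features does not fix the read-out at this position.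

The compounds shown leave open which part of the entering group goes with the rise: the tetramethyl pattern, the hydroxy group, the methylene link or the ring nitrogen without a side chain. As far as these compounds go, a plain (4-hydroxypiperidin-4-yl)methyl group, without the four methyl groups, would bear directly on that question, and how far compound 3 lies past its limit also stays unknown.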